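This account rests on a few compounds, and the source may have more. Where it says the series, first, only, none or still open, it means among the compounds named here.

Series in a functional assay on the whole organism with Scenedesmus acutus as the target, with a stated time of 20 h; on this read-out higher numbers stand for weaker inhibition and lower numbers for stronger inhibition:
- compound 1 `CCCOC(=O)c1cc(N2C(=O)C3=C(CCCC3)C2=O)ccc1Cl`: 661 nM
- compound 2 `CCC(C)OC(=O)c1cc(N2C(=O)C3=C(CCCC3)C2=O)ccc1Cl`: 9770 nM

Of the two numbers, the higher one belongs to compound 2, at 9770 nM, so it is the weaker inhibitor of the pair. The next change leads to compound 3 `CC(C)(C)OC(=O)c1cc(N2C(=O)C3=C(CCCC3)C2=O)ccc1Cl`, with tert-butyl in place of sec-butyl on an oxygen next to a carbonyl group. The two structures have the same atoms, joined differently. Within the data shown here, one measured step bears on this, a 15-fold higher number from compound 1 to compound 2 (1.17 log units; beyond the scatter), where methyl replaced hydrogen on the saturated chain carbon bound to that oxygen. That step was large and went towards weaker inhibition. A single step is thin support, so the same direction is expected in this assay, at a smaller size. The expected step is a 2.3-fold higher number from compound 2 to compound 3 (0.35 log units; beyond the scatter). For compound 3 the estimated value is 22000 nM, with an expected range from 7000 nM to 70000 nM.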

Compound 3, half-maximal inhibitory concentration: > 100000 nM
Compound 3: a limit, no number (the forecaster's own chance of this, stated with the estimate: 15%); middle value at least 4.5-fold (0.65 log units) from the limit.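

In this assay compound 3 sits at a limit and not at a number: the limit of > 100000 nM in this assay, at which 1 of the 3 values shown sits.

With the heavy-atom count unchanged, tert-butyl in place of sec-butyl on an oxygen next to a carbonyl group gives an at least 10-fold higher number from compound 2 to compound 3 (1.01 log units; beyond the scatter), so rearranging the same atoms is enough for a large step at this position. Measured from propyl, the change reaches an at least 150-fold higher number from compound 1 to compound 3 (2.17 log units; beyond the scatter), and propyl, sec-butyl and tert-butyl therefore run in one direction towards weaker inhibition, with none of the three going against it.

The limit of compound 3 leaves the true size of both steps open. Also open, on these data alone, is how a longer unbranched chain such as pentyl, or a ring such as cyclopentyl, would read on this oxygen.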